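The source may hold more compounds than are shown below. What is called first, only, known or untested is meant among the compounds shown, and "the series" means these compounds.

Series notes. Of the compounds shown here, three have been measured in a functional assay on HEK293 cells for agonist activity at D(4) dopamine receptor (Homo sapiens), read by FLIPR; a higher number here means that more compound is needed for the effect, a lower number that less compound is needed. Compound 1 `Cc1cc(C)cc(NC(=O)CN2CCC(c3cccc[n+]3[O-])CC2)c1` gives 52 nM. Compound 2 `COc1cc(C(=O)NCN2CCC(c3cccc[n+]3[O-])CC2)ccc1Cl` gives 159 nM, and compound 3 `COc1ccccc1C1CCN(CNC(=O)c2cccc(C)c2)CC1` gives 206 nM. Compound 1 thus stands at the lowest number of the three; its gap to compound 2 and its gap to compound 3 both lie beyond the usual scatter. Within the data shown here, no two measured compounds differ in only one place, so no single-change step among them can be read off.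

Compound 4 `O=C(CN1CCC(c2cccc[n+]2[O-])CC1)Nc1cccc(Cl)c1Cl` has not yet been measured in this assay. It differs from compound 1 in one place: 2,3-dichlorophenyl in place of 3,5-dimethylphenyl on an amide-type nitrogen. Among the measured compounds shown here, none of the measured compounds shows what exchanging 3,5-dimethylphenyl for 2,3-dichlorophenyl on the amide-type nitrogen does to the number, so the expectation rests on compound 1 alone. The expected 1.6-fold higher number from compound 1 to compound 4 (0.21 log units; within the scatter) is small, toward a somewhat higher number, and may well stay within the scatter. Compound 4 is accordingly estimated at 85 nM, with a range of 25 nM to 300 nM.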

Compound 4, half-maximal effective concentration: 180 nM
Beside the measured number, compound 4's estimate is 2.1-fold (0.33 log units) below it; low and high end bracket the measured number.
By their numbers in this assay, from the lowest: compound 1; then compounds 2, 4 and 3 (each within the scatter of the next).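

In this assay, among these compounds, the exchange of 3,5-dimethylphenyl for 2,3-dichlorophenyl on the amide-type nitrogen gives a 3.5-fold higher number from compound 1 to compound 4 (0.54 log units; beyond the scatter) and so provides the first single-change reading. The number at this position therefore responds to the aryl group it carries, even though the two groups match in heavy-atom count and ring type, and neither adds a hydrogen-bond donor, a hydrogen-bond acceptor or a net charge. No measured property of either group is available to account for this step.

The compounds shown leave open whether the step follows from chlorine in place of methyl or from the arrangement of the two groups on the ring. A 3,5-dichlorophenyl or 2,3-dimethylphenyl group on the same nitrogen would separate these two readings, and an unsubstituted phenyl would give a reference point for both.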